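Cyano in place of tert-butyl on the benzyl ring

The source may hold more compounds than are shown below. What is called first, only, known or untested is meant among the compounds shown, and "the series" means these compounds.

Compound 1 `COC(=O)c1ccc(NCc2cncn2Cc2ccc(Cl)cc2)cc1-c1ccccc1`, compound 2 `COC(=O)c1ccc(NCc2cncn2Cc2cccc(N)c2)cc1-c1ccccc1` and compound 3 `COC(=O)c1ccc(NCc2cncn2Cc2ccc(C(C)(C)C)cc2)cc1-c1ccccc1` share one core and differ only in the group on the benzyl ring. In a toxicity assay on NIH3T3 cells (Mus musculus) for cytotoxicity, read by resazurin assay (a lower number here means that less compound is needed, a higher number that more compound is needed for the effect), compound 1 gives 25000 nM. Compound 2 reaches only a limit of this assay, > 10000 nM. The step that the limit leaves unreadable from compound 1 to compound 2 therefore cannot be sized, as the limit of > 10000 nM in this assay, at which 1 of the 3 values shown sits, shows. Compound 3 has no result in this assay: "not determined" (no result reported). Compound 4 `COC(=O)c1ccc(NCc2cncn2Cc2ccc(C#N)cc2)cc1-c1ccccc1` differs from compound 3 by cyano in place of tert-butyl on an aromatic carbon. Going by the values given here, no measured step bears on this change, and compound 3 itself has no value, so the expectation rests on compound 1 alone. Compound 4 is expected to give about 25000 nM, within 8000 nM to 80000 nM, with a fair chance that only a limit is reported.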

Compound 4, half-maximal effective concentration: > 10000 nM
Compound 4: only a limit was reported (the forecaster's own chance of this, stated with the estimate: 50%); the middle value lies beyond the limit too.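

No new step can be read from compound 4 to compound 1 or compound 2 in this assay, as the values stop at a limit: the limit of > 10000 nM in this assay, at which 2 of the 4 values shown sit.

The compounds shown leave open whether cyano and chloro on the benzyl ring differ at all in this assay.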